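A few compounds are considered here, and "the series" means these few. Any claim that something is new, unique, unknown or untested is made for them only; others in the source may bear on it.

Measured so far:
Compound 1, `CCCCc1nc2cccc(C(=O)O)c2n1Cc1ccc(-c2ccccc2-c2noc(O)n2)cc1`: 64%
Compound 2, `CNc1nc2cccc(C(=O)O)c2n1Cc1ccc(-c2ccccc2-c2noc(O)n2)cc1`: 13%

Both compounds share one core and were tested in a functional assay on the whole organism for inhibition, with Rattus norvegicus as the target, with a stated time of 7 h, at a dose of 1 mg/kg by the oral route; on this read-out higher numbers stand for more inhibition at the one dose given (going by the name of the read-out) and lower numbers for less inhibition. Compound 2 stands lowest of the two numbers shown; its nearest neighbour is compound 1, and the step of a number 51 percentage points lower from compound 1 to compound 2 (beyond the scatter) is a large one and goes beyond the scatter of repeated measurements.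

Compound 3, `CCNc1nc2cccc(C(=O)O)c2n1Cc1ccc(-c2ccccc2-c2noc(O)n2)cc1`, has not yet been measured in this assay. It differs from compound 2 in one place: methyl in place of hydrogen on a saturated chain carbon bound to a nitrogen on an aromatic ring. Cut one bond further out, this reads as methylamino to ethylamino.

Going by the values given here, only one measured step exists, the one from compound 1 to compound 2, and it swaps a butyl for a methylamino group on an aromatic carbon. Among the compounds with values here, that is a different kind of change from adding a methyl to a chain carbon on the nitrogen, so it bears on the new step only loosely, and no step of exactly this kind has been measured. The expected step of a number 7 percentage points higher from compound 2 to compound 3 (within the scatter) is therefore small, likely within the scatter. Compound 3 is estimated at 20%, expected between 5% and 45%.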

Compound 3, a percentage reported as inhibition, in the whole organism at one dose (the size of the read-out at that dose, not a potency): 6%
Compound 3: middle estimate off by 14 percentage points, on the high side; measured number inside the range.
By their numbers in this assay, from the lowest: compounds 3 and 2 (each within the scatter of the next); then compound 1.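

In this assay, extending the methylamino group to ethylamino gives a number 7 percentage points lower from compound 2 to compound 3 (within the scatter), so adding this methyl to the chain on the nitrogen makes no difference that can be told from the usual scatter of this read-out. Ethylamino also falls far short of the butyl group on the same aromatic carbon, with a number 58 percentage points lower from compound 1 to compound 3 (beyond the scatter), which means the large gap first seen with methylamino is now seen with a second amino group. No measurement available here explains either step.

Going by these compounds, what stays open is whether the low numbers belong to the nitrogen attached to the aromatic carbon or to the shorter chain, since butyl differs from ethylamino in both respects; a propyl group at that place, with no nitrogen, and a butylamino group, with the longer chain kept on the nitrogen, would help to separate the two. Each number also comes from a single oral dose at a single time, so these compounds leave open how the groups would compare at other doses or times.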